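A few compounds are considered here, and "the series" means these few. Any claim that something is new, unique, unknown or untested is made for them only; others in the source may bear on it.

Of the compounds shown here, three have been tested in a functional assay on HEK293 cells for agonist activity at D(4) dopamine receptor (Homo sapiens), read by FLIPR; on this read-out higher numbers stand for larger maximal responses and lower numbers for smaller maximal responses. Compound 1 `Cc1cc(C)cc(NC(=O)CN2CCC(c3cccc[n+]3[O-])CC2)c1` gives 76%, compound 2 `O=C(CN1CCC(c2ccccn2)CC1)Nc1c(Cl)cc(Cl)cc1Cl` gives 45%, and compound 3 `O=C(NCN1CCC(c2cccc[n+]2[O-])CC1)c1cnccc1Cl` gives 44%. Compound 3 stands lowest of the three numbers, though its gap to compound 2 is within the scatter and only its gap to compound 1 lies beyond it. No pair among these three differs in just one place, so no single structural step has been measured.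

Compound 4 `Cc1cccc(C(=O)NCN2CCC(c3cccc[n+]3[O-])CC2)c1` has not been measured. It differs from compound 3 in one place: 3-methylphenyl in place of 4-chloropyridin-3-yl on a carbonyl carbon. Compound 1, which also carries a methyl-bearing benzene ring rather than a pyridine ring, gives the higher value 76%, although the rest of its structure is not the same as that of compound 3, so that comparison is only a loose guide. A modest rise is expected from compound 3 to compound 4 in this assay, on the order of a number 11 percentage points higher from compound 3 to compound 4 (beyond the scatter). Compound 4 is therefore estimated at 55%, most likely between 35% and 75%.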

Compound 4, largest response reached (reported as efficacy), in percent of the reference or control that the assay uses: 77%
Compound 4: middle estimate off by 22 percentage points, on the low side; the whole stated range lies below it.
By their numbers in this assay, from the lowest: compounds 3 and 2 (each within the scatter of the next); then compounds 1 and 4 (each within the scatter of the next).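

In this assay, placing 3-methylphenyl instead of 4-chloropyridin-3-yl on the carbonyl carbon gives a number 33 percentage points higher from compound 3 to compound 4 (beyond the scatter), so the group held at this place can strongly change the maximal response. The two groups have the same count of heavy atoms, so this step reflects a change in which atoms are present and not in their number: the ring that leaves holds a nitrogen and a chlorine, while the ring that enters is carbon only. Nothing shown here explains why the response differs across this step.

On these data alone, it remains open whether the chlorine, the ring nitrogen or the methyl accounts for the step, since all three change together. Unsubstituted phenyl, 4-chlorophenyl or pyridin-3-yl at this same place would help separate these contributions.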